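Adding isopropylcarbamoyl to the amine of compound 3

The source may report more compounds than this note shows. Statements on the series, on what has been measured and on what is new or still open speak of the compounds shown alone.

In a functional assay with Oryctolagus cuniculus as the target (a higher number here means a weaker inhibitor, a lower number a stronger inhibitor), compound 1 (`COc1ccc(-c2nc(/N=C(\N)NC3CCCCC3)sc2-c2ccc(OC)cc2)cc1`) gives > 1000 nM as a limit. Compound 2 (`COc1ccc(-c2nc(/N=C(\N)N3CCOCC3)sc2-c2ccc(OC)cc2)cc1`) gives < 1000 nM as a limit too. Compound 3 (`COc1ccc(-c2nc(CN)sc2-c2ccc(OC)cc2)cc1`) likewise stands only at the limit > 100 nM and has no exact number. Compound 4 (`COc1ccc(-c2nc(CNC(=O)NC(C)C)sc2-c2ccc(OC)cc2)cc1`) carries isopropylcarbamoyl in place of hydrogen on an amine nitrogen. Going by the values given here, three measured steps touch this region of the series, though none makes the same change. The step of a number no higher from compound 1 to compound 2 (the limit leaves the size open) has no readable size. The steps a step that the two limits leave unreadable from compound 1 to compound 3 and a step that the limit leaves unreadable from compound 2 to compound 3 are equally unreadable. No firm direction is therefore expected, and the estimated step (a step that the limit leaves unreadable from compound 3 to compound 4) is tentative. In this assay compound 4 is expected near 500 nM (estimated range 100 nM to 2500 nM).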

Compound 4, half-maximal inhibitory concentration: 42 nM
Compound 4: middle estimate off by 12-fold (1.08 log units), on the high side, outside the stated range (below it).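

Placing isopropylcarbamoyl on the amine nitrogen gives an at least 2.3-fold lower number from compound 3 to compound 4 (0.37 log units; beyond the scatter) in this assay, the first exact number in this series. Exchanging the whole group on the aromatic carbon for this open chain gives an at least 23-fold lower number from compound 1 to compound 4 (1.37 log units; beyond the scatter). Compound 2 stands only at a limit, and its step to compound 4 cannot be read: the limit of < 1000 nM in this assay, at which 1 of the 4 values shown sits.

Both readable steps give only a minimum size. The compounds shown leave open whether methyl or cyclohexyl in place of isopropyl, or acetyl in place of the whole isopropylcarbamoyl, would hold this number.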